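A Methyl for a Methoxy on the Chain

The source may report more compounds than this note shows. Statements on the series, on what has been measured and on what is new or still open speak of the compounds shown alone.

Of the compounds shown here, two of one shared core have been measured so far in an assay on isolated protein for inhibition of Amine oxidase [flavin-containing] A (Homo sapiens), read by fluorescence and Amplex Red, with a stated time of 30 min, tested at 10 uM; on this read-out lower numbers stand for a weaker effect and higher numbers for a stronger effect at the one concentration tested. Compound 1, `C=CCNc1nnc(SCC(=O)N(Cc2cccc([N+](=O)[O-])c2)c2ccc(F)cc2)s1`, gives 75.2%. Compound 2, `COCCNc1nnc(SCC(=O)N(Cc2cccc([N+](=O)[O-])c2)c2ccc(F)cc2)s1`, gives 80.6%. For the measured compounds named here, the one step between them, a number 5.4 percentage points higher from compound 1 to compound 2 (within the scatter), is a change of methoxymethyl in place of vinyl on a saturated chain carbon bound to a nitrogen on an aromatic ring, and its size is within the scatter. On the numbers shown, compound 2 stands highest of the two, with compound 1 nearest, although the gap between them lies within the scatter, so no order is claimed.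

The next compound, compound 3, is `CCCNc1nnc(SCC(=O)N(Cc2cccc([N+](=O)[O-])c2)c2ccc(F)cc2)s1`. It differs from compound 2 by methyl in place of methoxy on a saturated chain carbon, two bonds along the chain from a nitrogen on an aromatic ring. The methoxy leaves and a methyl enters, so compound 3 carries a propylamino chain where compound 2 carried a (2-methoxyethyl)amino chain.

Going by the values given here, only the step from compound 1 to compound 2 bears on this change, and it was within the scatter. For compound 3 the step of a number 4.6 percentage points lower from compound 2 to compound 3 (within the scatter) is therefore expected to be small, with no direction beyond the scatter. Compound 3 is estimated at 76%, with a range from 62% to 87%.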

Compound 3, a percentage reported as inhibition, at one concentration (the size of the read-out at that concentration, not a potency): 78.3%
Beside the measured number, compound 3's estimate is 2.3 percentage points below it; the measured number falls inside the stated range.
By their numbers in this assay, from the lowest: compounds 1, 3 and 2 (each within the scatter of the next).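

In this assay, the methoxy on this chain gives way to a methyl with a number 2.3 percentage points lower from compound 2 to compound 3 (within the scatter), so on these three compounds the ether oxygen of the (2-methoxyethyl)amino chain is not required for a read-out in this range at the one concentration tested. Ethyl in place of vinyl, on the saturated chain carbon bound to a nitrogen on an aromatic ring, gives a number 3.1 percentage points higher from compound 1 to compound 3 (within the scatter), so the three chains now compared at this position cannot be told apart in this assay, and no order among them can be drawn. No independent evidence bears on these values.

What the compounds shown leave open is whether this position stays as undemanding with a longer chain such as hexyl, a cyclohexyl ring on the nitrogen, or a terminal amine or carboxylic acid on the chain. All three values also come from a single concentration, so whether a difference in potency lies hidden among these chains remains unknown.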